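The source may report more compounds than this note shows. Statements on the series, on what has been measured and on what is new or still open speak of the compounds shown alone.

In a functional assay on PC-3 cells (Homo sapiens) for cytotoxicity (on this read-out higher numbers stand for weaker inhibition and lower numbers for stronger inhibition), compound 1 `Oc1ccccc1/C=N/c1nnc[nH]1` gives > 30000 nM as a limit of the assay and not as a number. Compound 2 `COc1ccc(/C=N/c2nnc[nH]2)cc1OC` gives > 30000 nM and this too is only a limit. Compound 3 `Brc1ccc(/C=N/n2cnnc2)cc1` gives > 30000 nM and this is again a limit. Compound 2 therefore has no number of its own: it stands with the other two at the limit of > 30000 nM in this assay, at which 3 of the 3 values shown sit, and no order among the three can be read from these results.

Going by the values given here, no measured pair differs in one place only, so the data offer no step size to carry over. As far as these compounds go, the compound still open is compound 4 `COc1ccc(/C=N/n2cnnc2)cc1OC` which has the same atoms as compound 2 joined differently. The change is 4H-1,2,4-triazol-4-yl in place of 4H-1,2,4-triazol-3-yl on a double-bonded nitrogen and it is the only thing separating the two.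

The entering 4H-1,2,4-triazol-4-yl is already present in compound 3 whose > 30000 nM is also a limit. On that ground no shift beyond the scatter is expected in this assay and the expected a number no higher from compound 2 to compound 4 (the limit leaves the size open) stays small. For compound 4 the estimate is 30000 nM with an expected range from 12000 nM to 60000 nM and another report as a limit is the likely outcome.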

Compound 4, half-maximal inhibitory concentration: > 30000 nM
Compound 4: a limit, no number; the forecaster's own chance of this, stated with the estimate: 75%; the middle value sits exactly at the limit.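

In this assay compound 4 gives > 30000 nM, which is a limit and not a number. No step can be read between compound 2 and compound 4, and the same holds across the series: the limit of > 30000 nM in this assay, at which 4 of the 4 values shown sit. The compounds shown leave open whether the swap between the two triazolyl groups changes cytotoxicity at all, and how the compounds rank.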